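The compounds below may be only part of what the source reports. "The series", "measured", "known", "first", "only" and "open" are said of these compounds alone.

In a functional assay on MDA-MB-231 cells (Homo sapiens) for antiproliferative activity, read by MTT assay, with a stated time of 48 h (a lower number here means a stronger inhibitor, a higher number a weaker inhibitor), compound 1 `Cc1c(C(=O)NCCS(C)(=O)=O)oc2ccc(N(Cc3ccc(Br)cc3)S(=O)(=O)c3ccc(Br)cc3)cc12` reads > 40000 nM, which is a limit of the assay and not a number; the limit of > 40000 nM in this assay, at which 1 of the 2 values shown sits, records this limit. Going by the values given here, compound 2 `Cc1c(C(=O)N2CCCC(C)C2)oc2ccc(N(Cc3ccc(Br)cc3)S(=O)(=O)c3ccc(Br)cc3)cc12` gives 19400 nM, the only actual number so far.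

Compound 3 `Cc1ccc(NC(=O)c2oc3ccc(N(Cc4ccc(Br)cc4)S(=O)(=O)c4ccc(Br)cc4)cc3c2C)nc1` differs from compound 2 by (5-methylpyridin-2-yl)amino in place of 3-methylpiperidin-1-yl on a carbonyl carbon. The same difference reads as (3-methylpiperidin-1-yl)carbonyl to (5-methylpyridin-2-yl)carbamoyl.

Among the compounds with values here, only one measured step bears on this change: an at least 2.0-fold lower number from compound 1 to compound 2 (0.31 log units; beyond the scatter). It acts at the same place and is modest, and its size is only a bound, set by the limit on compound 1. Within the data shown here, it shows that the group on the carbonyl carbon can move the number in this assay, but no measured step starts from 3-methylpiperidin-1-yl or introduces (5-methylpyridin-2-yl)amino. No clear direction can be drawn from it, so no shift beyond the scatter is expected.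

The expected change is a 1.3-fold lower number from compound 2 to compound 3 (0.11 log units; within the scatter). For compound 3 the estimated value is 15000 nM, with an expected range of 5000 nM to 40000 nM.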

Compound 3, half-maximal inhibitory concentration: > 40000 nM
Compound 3 was reported as a limit; the forecaster's own chance of this, stated with the estimate: 20%; at least 2.6-fold (0.42 log units) between middle value and limit.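

In this assay, going by these compounds alone, (5-methylpyridin-2-yl)amino in place of 3-methylpiperidin-1-yl on the carbonyl carbon gives an at least 2.0-fold higher number from compound 2 to compound 3 (0.31 log units; beyond the scatter), so this change at this position costs activity, where the earlier step showed only that the group here can move the number. The value of compound 3 is a limit of the assay and not a number, and the step from compound 1 to compound 3 cannot be read, as both ends are limits. Of the three compounds, only compound 2, the one without an amide hydrogen, gives an actual number, while compound 1 and compound 3 both carry that hydrogen and both sit at the limit: the limit of > 40000 nM in this assay, at which 2 of the 3 values shown sit.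

Two features change together from compound 2 to compound 3, the amide hydrogen and the exchange of a non-aromatic ring for an aromatic one, and these compounds cannot separate them. A morpholin-4-yl or an unsubstituted piperidin-1-yl on the carbonyl carbon would test how much depends on the ring itself, and a cyclohexylamino or an N-methyl-N-(5-methylpyridin-2-yl)amino would test the amide hydrogen apart from the ring.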